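The compounds below may be only part of what the source reports. "The series", "measured", "known", "first", "only" and "open" are said of these compounds alone.

The series at hand consists of three measured compounds and one that awaits its number. Compound 1 `CCOC(=O)c1cnn(-c2nc(-c3ccc(OC)cc3)c(C#N)c(=O)n2C)c1N` carries a 4-methoxyphenyl group on its core. In a functional assay, with a stated time of 150 min (a higher number here means a weaker inhibitor, a lower number a stronger inhibitor), compound 1 gives 79 ug/mL. Compound 2 `CN(C)c1ccc(-c2nc(NN)n(C)c(=O)c2C#N)cc1` gives 69 ug/mL in this assay, and compound 3 `Cn1c(NN)nc(-c2ccccc2O)c(C#N)c1=O` gives 46 ug/mL. Compound 1 thus holds the highest of the three numbers, yet its gaps to compound 2 and to compound 3 both lie within the usual scatter of repeated measurements, so the three compounds cannot be told apart on these data.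

Compound 4 `CCOC(=O)c1cnn(-c2nc(-c3ccco3)c(C#N)c(=O)n2C)c1N` is the unmeasured member. It differs from compound 1 in a single place: furan-2-yl in place of 4-methoxyphenyl on an aromatic carbon. A five-membered aromatic ring with one hetero atom takes the place of a six-membered aromatic ring of carbon only, and the count of hydrogen-bond acceptors does not change.

Going by the values given here, no pair of measured compounds that differ in one place is available, so nothing here shows how such a swap moves the number. The three measured values cluster closely, which gives no ground for expecting a large move in either direction. The step from compound 1 to compound 4 is therefore expected to be a 1.1-fold lower number from compound 1 to compound 4 (0.02 log units; within the scatter), none beyond the scatter. Compound 4 is estimated to give 75 ug/mL in this assay, within a range from 35 ug/mL to 160 ug/mL.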

Compound 4, half-maximal inhibitory concentration: 108 ug/mL
For compound 4 the middle estimate is 1.4-fold (0.16 log units) below the measured one; the range from low to high includes it.
By their numbers in this assay, from the lowest: compounds 3, 2, 1 and 4 (each within the scatter of the next, the first and the last beyond it).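

Going by these compounds alone, the first step that changes one place only is the swap of 4-methoxyphenyl for furan-2-yl on an aromatic carbon ortho to a cyano group and next to the ring nitrogen, and in this assay it gives a 1.4-fold higher number from compound 1 to compound 4 (0.14 log units; within the scatter). This shows that, on the core of compound 1, a five-membered aromatic ring with 1 hetero atom and a six-membered aromatic ring of carbon only cannot be told apart at this position, even though the entering group has fewer heavy atoms than the group that leaves. Nothing measured here bears on why the two groups give numbers within the scatter of each other.

The compounds shown leave open whether a group of another kind at this position, such as an unsubstituted phenyl, a thiophene, an amine, a carboxylic acid or a longer alkyl chain, would give a step beyond the scatter. They also leave open whether the same swap would give a similar step on the cores of compound 2 and compound 3, which differ from compound 1 in more than one place.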